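Lactam Amide to Methylazetidine Amide on a Shared Core

This account rests on a few compounds, and the source may have more. Where it says the series, first, only, none or still open, it means among the compounds named here.

The measured compounds are:
compound 1, `Cn1cc(CNS(=O)(=O)c2ccccc2Nc2cc(-c3ccc4ccn(C)c4c3)c3nccnc3c2)cn1`
compound 2, `Cn1ccc2ccc(-c3cc(Nc4cnccc4C(=O)NCc4cncnc4)cc4nccnc34)cc21`
compound 3, `Cn1ccc2ccc(-c3cc(Nc4cnccc4C(=O)NC4CCNC(=O)C4)cc4nccnc34)cc21`

In an assay on lysate for inhibition of 6-phosphofructo-2-kinase/fructose-2,6-bisphosphatase 3 (Homo sapiens), with stated times of 0.5 min and 45 min (a higher number here means a weaker inhibitor, a lower number a stronger inhibitor), compound 1 gives only a limit, > 100000 nM, and no number. In this assay compound 2 gives 49500 nM. In this assay compound 3 gives 56500 nM. Compound 3 thus holds the higher of the two numbers that are known, but the step of a 1.1-fold higher number from compound 2 to compound 3 (0.06 log units; within the scatter) is within the scatter, so compound 2 and compound 3 cannot be told apart on these data.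

Compound 4, `CN1CC(NC(=O)c2ccncc2Nc2cc(-c3ccc4ccn(C)c4c3)c3nccnc3c2)C1`, differs from compound 3 by 1-methylazetidin-3-yl in place of 2-oxopiperidin-4-yl on an amide-type nitrogen. For the measured compounds named here, the only measured step that bears on this position is the one from compound 2 to compound 3, which also exchanged the group on the amide-type nitrogen, and it stayed within the scatter. On that basis the step of a 1.0-fold lower number from compound 3 to compound 4 (0.01 log units; within the scatter) in this assay is expected to be small, with no direction beyond the scatter. Compound 4 is therefore estimated at 55000 nM, within a range of 20000 nM to 150000 nM.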

Compound 4, half-maximal inhibitory concentration: 9190 nM
Beside the measured number, compound 4's estimate is 6.0-fold (0.78 log units) above it; measured number outside the range, below it.
By their numbers in this assay, from the lowest: compound 4; then compounds 2 and 3 (each within the scatter of the next). At a limit, above all of these: compound 1.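

In this assay the group on the amide-type nitrogen turns out to be able to shift the number: 1-methylazetidin-3-yl in place of 2-oxopiperidin-4-yl gives a 6.1-fold lower number from compound 3 to compound 4 (0.79 log units; beyond the scatter), and in place of (pyrimidin-5-yl)methyl it gives a 5.4-fold lower number from compound 2 to compound 4 (0.73 log units; beyond the scatter). The earlier pair could not show this, since compound 2 and compound 3 carry very different groups here yet cannot be told apart, whereas compound 4 stands clear of both. Nothing measured among the compounds shown accounts for the gain.

On these data alone, it stays open whether the four-membered ring or the methyl group on its nitrogen carries the change. Plain azetidin-3-yl, 1-methylpyrrolidin-3-yl or 1-methylpiperidin-4-yl on the same amide-type nitrogen would begin to separate the two.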